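Swapping an acetamidoethyl for cycloheptyl on the amide nitrogen

The source may report more compounds than this note shows. Statements on the series, on what has been measured and on what is new or still open speak of the compounds shown alone.

Of the compounds shown here, three sharing one core have been measured in an assay on cell membranes for binding affinity to 2-oxoglutarate receptor 1 (Rattus norvegicus), read by radioligand binding; on this read-out lower numbers stand for stronger inhibition and higher numbers for weaker inhibition. Compound 1 `CCCCCCNC(=O)[C@H]1OC(n2cnc3c(N)ncnc32)[C@H](O)[C@@H]1O` gives 19 nM, and compound 2 `CCCCCCCNC(=O)[C@H]1OC(n2cnc3c(N)ncnc32)[C@H](O)[C@@H]1O` gives 20 nM; the step of a 1.1-fold higher number from compound 1 to compound 2 (0.02 log units; within the scatter) lies within the scatter. Compound 3 `CC(=O)NCCNC(=O)[C@H]1OC(n2cnc3c(N)ncnc32)[C@H](O)[C@@H]1O` gives 46 nM, the highest of the three numbers: it sits a 2.4-fold higher number from compound 1 to compound 3 (0.38 log units; beyond the scatter) and a 2.3-fold higher number from compound 2 to compound 3 (0.36 log units; beyond the scatter), both modest but beyond the scatter.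

Compound 4 `Nc1ncnc2c1ncn2C1O[C@H](C(=O)NC2CCCCCC2)[C@@H](O)[C@H]1O` has not yet been measured. It differs from compound 3 in one place: cycloheptyl in place of 2-acetamidoethyl on an amide-type nitrogen. The two measured steps that bear on this change both run the other way: in each of them a chain of carbon only was replaced by one carrying an acetamido group, and each raised the number by a modest but clear amount. Compound 4 again carries a group of carbon only on that nitrogen, here a seven-membered non-aromatic ring rather than a chain, so the expected movement is back down by a similar modest amount, giving an estimated 2.3-fold lower number from compound 3 to compound 4 (0.36 log units; beyond the scatter). On that basis compound 4 is expected to give about 20 nM, in the range 7 nM to 60 nM.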

Compound 4, inhibition constant: 22 nM
The estimate for compound 4 lay 1.1-fold (0.04 log units) below the measured number, and the stated range covers the measured number.
By their numbers in this assay, from the lowest: compounds 1, 2 and 4 (each within the scatter of the next); then compound 3.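

In this assay, closing the carbon chain into a seven-membered ring leaves no readable mark: cycloheptyl in place of heptyl on the amide-type nitrogen gives (a 1.1-fold higher number from compound 2 to compound 4 (0.04 log units; within the scatter)), and cycloheptyl in place of hexyl gives (a 1.2-fold higher number from compound 1 to compound 4 (0.06 log units; within the scatter)). The change from 2-acetamidoethyl to cycloheptyl gives (a 2.1-fold lower number from compound 3 to compound 4 (0.32 log units; beyond the scatter)), so the earlier link between a carbon-only group and the lower number now extends from open chains to a ring, and among these four compounds 2-acetamidoethyl alone stands apart. Nothing shown here explains why the ring and the chains match or why compound 3 differs from them.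

Among these compounds, a plain ethyl group on the same nitrogen would be needed to separate the effect of the acetamido group from that of the shorter chain, since compound 3 is the only compound here with either feature. Going by these compounds, it also remains open whether a small ring such as cyclopropyl, a very short chain such as methyl, or a hexyl chain ending in an amine or a carboxylic acid would stay at this level.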